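Swapping the sulfonyl-bound ring for a pyrimidine

The compounds below may be only part of what the source reports. "The series", "measured", "known", "first", "only" and "open" are said of these compounds alone.

Of the compounds shown here, three sharing one core have been tested in a functional assay (Cavia porcellus) with sulfonylurea receptors; K-ATP channels (Homo sapiens) as the target; a lower number here means a stronger inhibitor, a higher number a weaker inhibitor. Compound 1 `CC(O)(C(=O)Nc1ccc(S(=O)(=O)c2cccc(F)c2)cc1)C(F)(F)F` gives 3400 nM. Compound 2 `CC(O)(C(=O)Nc1ccc(S(=O)(=O)c2ccc(F)cc2)cc1)C(F)(F)F` gives 8600 nM, and compound 3 `CC(O)(C(=O)Nc1ccc(S(=O)(=O)c2ccccc2Cl)cc1)C(F)(F)F` gives 2300 nM. Among these three numbers compound 3 has the lowest; its nearest neighbour is compound 1, with a 1.5-fold lower number from compound 1 to compound 3 (0.17 log units; within the scatter), and the furthest is compound 2, with a 3.7-fold lower number from compound 2 to compound 3 (0.57 log units; beyond the scatter). The move from compound 1 to compound 2 gave a 2.5-fold higher number from compound 1 to compound 2 (0.40 log units; beyond the scatter).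

The next compound, compound 4 `CC(O)(C(=O)Nc1ccc(S(=O)(=O)c2cncnc2)cc1)C(F)(F)F`, changes the ring on the sulfonyl sulfur again: pyrimidin-5-yl in place of 2-chlorophenyl on a sulfonyl sulfur. The three measured steps all concern one carbon-only ring replaced by another carbon-only ring, and none of them introduces a ring with hetero atoms, so they bear on this change only loosely. They show that swapping the ring on the sulfonyl sulfur moves this assay by modest amounts in either direction. The expectation is therefore a modest step, more likely towards a higher number, giving a 2.6-fold higher number from compound 3 to compound 4 (0.42 log units; beyond the scatter). Compound 4 is estimated at 6000 nM, with a range from 2000 nM to 20000 nM.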

Compound 4, half-maximal inhibitory concentration: > 30000 nM
Compound 4: only a limit was reported; the forecaster's own chance of this, stated with the estimate: 10%; middle value at least 5.0-fold (0.69 log units) away from the limit.
By their numbers in this assay, from the lowest: compounds 3 and 1 (each within the scatter of the next); then compound 2. At a limit, above all of these: compound 4.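

In this assay compound 4 gives no number, only a limit of the assay: the limit of > 30000 nM in this assay, at which 1 of the 4 values shown sits. Pyrimidin-5-yl, the only ring on the sulfonyl sulfur here with hetero atoms, gives an at least 13-fold higher number from compound 3 to compound 4 (1.11 log units; beyond the scatter), along with an at least 3.4-fold higher number from compound 2 to compound 4 (0.54 log units; beyond the scatter) and an at least 8.8-fold higher number from compound 1 to compound 4 (0.94 log units; beyond the scatter). All three steps point the same way and lie beyond the scatter, so this position, where the carbon-only rings differ by modest steps at most, responds much more strongly to this change than to any swap among those rings.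

With only one such ring shown, the result cannot separate the effect of the ring's nitrogen atoms from that of losing the halogen substituent. As far as these compounds go, whether a pyridine ring, with a single nitrogen, would fall with the carbon-only rings or with compound 4 also stays open.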